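The source may report more compounds than this note shows. Statements on the series, on what has been measured and on what is new or still open speak of the compounds shown alone.

Measured so far in an ADME assay on Raji cells (Homo sapiens) for cytotoxicity, read by luminescence, with a stated time of 72 h; a higher number here means that more compound is needed for the effect, a lower number that less compound is needed:
- Compound 1 `CCOC(=O)c1c(-c2cccc(-c3ccccc3)c2)[nH]c2cc(OC)ccc2c1=O`: > 21500 nM
- Compound 2 `CCOC(=O)c1c(-c2cccc(-c3ccccc3)c2)[nH]c2cc(OC)c(OC)cc2c1=O`: > 21500 nM
- Compound 3 `CCOC(=O)c1c(-c2cccc(-c3ccccc3)c2)[nH]c2cc(OC)c(Cl)cc2c1=O`: > 21500 nM

Each of these entries is a limit of the assay and not a number. Compound 3 therefore has no exact place on the scale. The three compounds share one reading, (the limit of > 21500 nM in this assay, at which 3 of the 3 values shown sit), and none goes against it.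

The next compound, compound 4 `CCOC(=O)c1c(-c2cccc(-c3ccccc3)c2)[nH]c2cc(OC)c(F)cc2c1=O`, changes the shared core in one place: fluoro in place of chloro on an aromatic carbon. The carbon that changes lies ortho to a methoxy group.

Two measured steps change that same carbon: a step that the two limits leave unreadable from compound 1 to compound 3 and a step that the two limits leave unreadable from compound 2 to compound 3. Neither has a readable size. They show only that hydrogen, methoxy and chloro there all leave the reading at the limit. Among the measured compounds shown here, no measured step involves fluoro.

In this assay, no step beyond the scatter and no particular direction is expected, since compound 3 gives only the limit > 21500 nM. The expected step is a step that the limit leaves unreadable from compound 3 to compound 4. A further limit is the most likely report. For compound 4 the estimate is 25000 nM, with an expected range from 15000 nM to 45000 nM.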

Compound 4, half-maximal effective concentration: > 21500 nM
Compound 4 gave a limit, no number; the forecaster's own chance of this, stated with the estimate: 88%; the middle value lies beyond the limit too.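

Like compound 1, compound 2 and compound 3, compound 4 gives only a limit and not a number in this assay, so no step among these four compounds can be read: the limit of > 21500 nM in this assay, at which 4 of the 4 values shown sit.

The compounds shown leave open how much of each is needed for the effect, and whether any group on this carbon would bring a reading inside the limit.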